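A few compounds are considered here, and "the series" means these few. Any claim that something is new, unique, unknown or untested is made for them only; others in the source may bear on it.

Compound 1 `CCOCCCCCCCCCc1cc2cn([C@@H]3CC[C@H](CO)O3)c(=O)nc2o1` is the reference point here. In an ADME assay on HFFF cells (Homo sapiens) for cytotoxicity, read by luminescence (on this read-out lower numbers stand for higher toxicity in this test and higher numbers for lower toxicity in this test), compound 1 gives > 100000 nM, which is a limit of the assay and not a number. Compound 2 `CCCOCCCCCCCCCc1cc2cn([C@@H]3CC[C@H](CO)O3)c(=O)nc2o1` gives > 100000 nM, also a limit. Compound 3 `CCCCCOCCCCCCCCCc1cc2cn([C@@H]3CC[C@H](CO)O3)c(=O)nc2o1` gives > 100000 nM, again a limit. Together these results form (the limit of > 100000 nM in this assay, at which 3 of the 3 values shown sit), so compound 1 has no measured neighbour that sets it apart.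

Compound 4 `CCCCCCOCCCCCCCCCc1cc2cn([C@@H]3CC[C@H](CO)O3)c(=O)nc2o1` differs from compound 1 by butyl in place of hydrogen on a saturated chain carbon, two bonds along the chain from an oxygen on a saturated carbon. In words, butyl takes the place of hydrogen on a saturated chain carbon, two bonds along the chain from an oxygen on a saturated carbon. The same difference can also be read as ethoxy to hexyloxy.

The closest measured changes are of the same kind, but none has a readable size. They are a step that the two limits leave unreadable from compound 1 to compound 2, a step that the two limits leave unreadable from compound 1 to compound 3 and a step that the two limits leave unreadable from compound 2 to compound 3. With no measured size to carry forward, no change beyond the scatter is expected in this assay, and no direction can be assigned. The expected result is a number no higher from compound 1 to compound 4 (the limit leaves the size open), and a further limit is the likeliest report. Compound 4 is estimated at 100000 nM, with an expected range from 50000 nM to 200000 nM.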

Compound 4, half-maximal cytotoxic concentration: > 100000 nM
Compound 4 ended at the assay's limit (the forecaster's own chance of this, stated with the estimate: 85%); the middle value sits exactly at the limit.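

No step can be read from compound 4 to compound 1, compound 2 or compound 3, as all four results are limits and not numbers in this assay: the limit of > 100000 nM in this assay, at which 4 of the 4 values shown sit.

The compounds shown leave open where the half-maximal cytotoxic concentration of each one lies, and whether going from ethoxy to hexyloxy changes it at all.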